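A Stereocentre Left Undrawn, Measured Against a Toxicity Limit

This account rests on a few compounds, and the source may have more. Where it says the series, first, only, none or still open, it means among the compounds named here.

Of the compounds shown here, three have been tested so far in an ADME assay on HepG2 2.2.15 cells (Homo sapiens) for cytotoxicity, read by MTT assay, with a stated time of 8 days; on this read-out lower numbers stand for higher toxicity in this test and higher numbers for lower toxicity in this test. Compound 1 `COC(=O)C1=C(C)NC(c2ncc(F)cc2F)=N[C@H]1c1ccc(F)cc1Cl` reads > 5000 nM, which is a limit of the test and not a number. Compound 3 `Cc1ccc(-c2nn(Cc3ccc(C#N)cc3)c(=O)c3ccccc23)c(F)n1` reads > 100000 nM, which is also a limit. Compound 2 `N#Cc1ccc(Cn2nc(-c3cc(Cl)c(NC[C@H](O)CO)nc3F)c3ccccc3c2=O)cc1` reads > 100000 nM, again a limit. Compound 2 therefore has no exact number: it sits at the limit of > 100000 nM in this assay, at which 2 of the 3 values shown sit. The only other limit sits at the limit of > 5000 nM in this assay, at which 1 of the 3 values shown sits.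

Compound 4 `N#Cc1ccc(Cn2nc(-c3cc(Cl)c(NCC(O)CO)nc3F)c3ccccc3c2=O)cc1` has not yet been measured. A stereocentre is a carbon whose attached groups can be arranged in two mirror-image ways, and that is the only place where the drawings of these two compounds part: the two compounds have the same atoms and bonds; at least one stereo element is drawn with a configuration in one of them and without one in the other: 1 of 1 stereo elements differ; a stereocentre at a saturated chain carbon is drawn S in compound 2 and without a configuration in compound 4. Within the data shown here, no pair of tested compounds shows what such a difference does in this test. With the atoms and bonds unchanged, the expected size of the step of a number no higher from compound 2 to compound 4 (the limit leaves the size open) is nothing beyond the usual scatter, and no direction is expected. This expectation rests on compound 2 and its limit of > 100000 nM, and a limit is also the most likely report for the new compound. Compound 4 is estimated at 100000 nM, with an expected range from 60000 nM to 200000 nM.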

Compound 4, half-maximal cytotoxic concentration: > 100000 nM
Compound 4: no number, only a limit; the forecaster's own chance of this, stated with the estimate: 90%; the middle value sits exactly at the limit.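

No step can be read from compound 2 to compound 4 in this assay, since each reports a limit and not a number: the limit of > 100000 nM in this assay, at which 3 of the 4 values shown sit.

The compounds shown leave open whether drawing the saturated chain carbon as S, or without a configuration, goes with any difference in toxicity in this assay.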